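This account rests on a few compounds, and the source may have more. Where it says the series, first, only, none or still open, it means among the compounds named here.

In a functional assay (muscle tissue) with Cavia porcellus as the target (on this read-out higher numbers stand for an effect only at larger amounts of compound and lower numbers for an effect already at smaller amounts), compound 3 (`COC(=O)C1=C(C)N=C(C)/C(=C(\O)OC)C1c1ccc(Br)cc1`) gives 540 nM, the highest of three numbers, against compound 1 (`COC(=O)C1=C(C)N=C(C)/C(=C(\O)OC)C1c1cccc(OC)c1`) at 191 nM and compound 2 (`COC(=O)C1=C(C)N=C(C)/C(=C(\O)OC)C1c1ccccc1Br`) at 7.59 nM. Compound 4 (`COC(=O)C1=C(C)N=C(C)/C(=C(\O)OC)C1c1ccc(Cl)cc1Cl`) carries 2,4-dichlorophenyl in place of 4-bromophenyl on a saturated ring carbon. Its group combines the halogen placement of compound 3 with that of compound 2, so the large step of a 71-fold higher number from compound 2 to compound 3 (1.85 log units; beyond the scatter), read in reverse, bears most directly. The large step of a 25-fold lower number from compound 1 to compound 2 (1.40 log units; beyond the scatter) points the same way, while a 2.8-fold higher number from compound 1 to compound 3 (0.45 log units; beyond the scatter) is only modest. Among the compounds with values here, no measured compound carries chlorine, so a large step to a lower number is expected, though probably not the full reverse. The expected change is a 14-fold lower number from compound 3 to compound 4 (1.13 log units; beyond the scatter). Compound 4 is estimated at 40 nM, within an expected range of 9 nM to 180 nM.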

Compound 4, half-maximal effective concentration: 640 nM
Compound 4: middle estimate off by 16-fold (1.20 log units), on the low side, and the stated range ends below it.
By their numbers in this assay, from the lowest: compound 2; then compound 1; then compounds 3 and 4 (each within the scatter of the next).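

In this assay, 2,4-dichlorophenyl does not keep the low number seen with 2-bromophenyl, showing an 84-fold higher number from compound 2 to compound 4 (1.93 log units; beyond the scatter), whereas the change from 4-bromophenyl shows a 1.2-fold higher number from compound 3 to compound 4 (0.07 log units; within the scatter). Against the 3-methoxyphenyl group, it shows a 3.4-fold higher number from compound 1 to compound 4 (0.53 log units; beyond the scatter), so among these compounds the low number remains with compound 2 alone. No measurement given here accounts for this difference. From the compounds shown here alone, it remains open whether 2-chlorophenyl would match 2-bromophenyl or 2,4-dichlorophenyl. Going by these compounds, how 2-methoxyphenyl or 2-aminophenyl would read at this ring carbon also remains open.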